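Methyl on an aromatic carbon: effect on efficacy in the series

The compounds below may be only part of what the source reports. "The series", "measured", "known", "first", "only" and "open" are said of these compounds alone.

Compound 1 `C[C@@H](NC(=O)c1ccc(C#Cc2ccccc2)cn1)C(C)(C)O` gives 43.2% in an ADME assay on HEK293 cells for agonist activity at metabotropic glutamate receptor 5 (Rattus norvegicus), read by fluorescence and calcium flux; a higher number here means a larger maximal response, a lower number a smaller maximal response. Compound 2 `Cc1ccccc1C#Cc1ccc(C(=O)N[C@H](C)C(C)(C)O)nc1` carries the change methyl in place of hydrogen on an aromatic carbon and gives 24.1%; the step is a number 19.1 percentage points lower from compound 1 to compound 2 (beyond the scatter). Compound 3 `C[C@@H](NC(=O)c1ccc(C#Cc2cccc(F)c2)nc1)C(C)(C)O` gives 26.6%; the difference between the cores of compound 3 and compound 1 is not broken down here. Compound 4 `Cc1nc(C#Cc2cccc(F)c2)ccc1C(=O)N[C@H](C)C(C)(C)O` is unmeasured and differs from compound 3 by methyl in place of hydrogen on an aromatic carbon. This is the same kind of change as that from compound 1 to compound 2, not the same: there the methyl enters a six-membered aromatic ring of carbon only, ortho to a large group, here a six-membered aromatic ring with 1 nitrogen, next to the ring nitrogen. For compound 4 a step of a number 11.6 percentage points lower from compound 3 to compound 4 (beyond the scatter) is expected, in the same direction as the measured one because a number 19.1 percentage points lower from compound 1 to compound 2 (beyond the scatter) lowered the efficacy, though with wide uncertainty given the different place. Compound 4 is estimated at 15%, between 4% and 28%.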

Compound 4, largest response reached (reported as efficacy), in percent of the reference or control that the assay uses: 9.2%
Compound 4: the middle estimate sits 5.8 percentage points above what was measured; measured number inside the range.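

In this assay the new step is a number 17.4 percentage points lower from compound 3 to compound 4 (beyond the scatter). Set beside the earlier step, the change carries from one core to the other with no difference in size that can be told apart: the same change on two cores in this assay, a number 19.1 percentage points lower (beyond the scatter) from compound 1 to compound 2 and a number 17.4 percentage points lower (beyond the scatter) from compound 3 to compound 4, 1.7 percentage points apart, within the scatter of two such steps. This rests on two pairs only, with the methyl at a different place in each, so it gives no general rule for other cores and does not explain why the maximal response falls.

On these data alone, whether an ethyl group, a methoxy group or an amine on the same aromatic carbon lowers the maximal response as the methyl does stays open. Also open, as far as these compounds go, is whether the methyl has this effect on other cores.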